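This account rests on a few compounds, and the source may have more. Where it says the series, first, only, none or still open, it means among the compounds named here.

Three compounds share one core and differ only in the chain on the aromatic nitrogen. Compound 1 `COCCn1nc(C(=O)N[C@H]2COc3ccccc3N(C)C2=S)nc1Cc1ccccc1` carries a methoxy on that chain, compound 2 `CN1C(=S)[C@@H](NC(=O)c2nc(Cc3ccccc3)n(CCCO)n2)COc2ccccc21` a hydroxy, and compound 3 `CN1C(=S)[C@@H](NC(=O)c2nc(Cc3ccccc3)n(CCCCCC#N)n2)COc2ccccc21` a chain ending in a nitrile. In a toxicity assay on HT-29 cells (Homo sapiens) for cytotoxicity (a lower number here means that less compound is tolerated, a higher number that more compound is tolerated), compound 1 gives only a limit of the assay, > 100000 nM. In this assay compound 2 likewise reaches only a limit, > 100000 nM. In this assay compound 3 too stops at a limit, > 100000 nM. The steps between these three therefore cannot be read: a step that the two limits leave unreadable from compound 1 to compound 2, a step that the two limits leave unreadable from compound 1 to compound 3, and a step that the two limits leave unreadable from compound 2 to compound 3. Compound 3 stands at the limit of > 100000 nM in this assay, at which 3 of the 3 values shown sit, as do the other two.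

Compound 4 `CN1C(=S)[C@@H](NC(=O)c2nc(Cc3ccccc3)n(CC3CCOC3)n2)COc2ccccc21` differs from compound 3 in one place: oxolan-3-yl in place of 4-cyanobutyl on a saturated chain carbon bound to an aromatic nitrogen. Among the measured compounds shown here, no measured step gives a readable size for any change on this chain, so none of them bears on this change beyond showing that three different chains all sit at the same limit. For compound 4 the expected step of a number no higher from compound 3 to compound 4 (the limit leaves the size open) is therefore none beyond the scatter, with another limit the likeliest outcome. Compound 4 is estimated at 100000 nM, within a range from 50000 nM to 300000 nM in this assay.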

Compound 4, half-maximal cytotoxic concentration: > 100000 nM
Compound 4 ended at the assay's limit; the forecaster's own chance of this, stated with the estimate: 85%; the middle value lies on the limit itself.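

In this assay compound 4 also gives only a limit, > 100000 nM. Its steps from compound 1, compound 2 and compound 3 therefore cannot be read, and all the compounds stand together: the limit of > 100000 nM in this assay, at which 4 of the 4 values shown sit.

The compounds shown leave open whether these chains differ at all in this read-out: each of them gives a limit, not a number.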